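Returning an aromatic ring to the amide of compound 2

The source may hold more compounds than are shown below. What is called first, only, known or untested is meant among the compounds shown, and "the series" means these compounds.

Compound 1 `O=C(Nc1ccc2nc(NC(=O)C3CCCCC3)sc2c1)c1ccccc1C(F)(F)F` and compound 2 `CCCC(C)C(=O)Nc1ccc2nc(NC(=O)C3CCCCC3)sc2c1` share a core and differ at one carbonyl carbon. In a functional assay on WI-38 VA13 cells (Homo sapiens) for cytotoxicity (a higher number here means that more compound is needed for the effect, a lower number that less compound is needed), compound 1 gives 0.024 ug/mL, while compound 2 gives 0.14 ug/mL, the higher of the two numbers, with a 5.8-fold higher number from compound 1 to compound 2 (0.77 log units; beyond the scatter). Compound 3 `Cc1cc(C(=O)Nc2ccc3nc(NC(=O)C4CCCCC4)sc3c2)c(C)n1C` carries the change (1,2,5-trimethyl-1H-pyrrol-3-yl in place of 1-methylbutyl on a carbonyl carbon). For the measured compounds named here, the only relevant step is that from compound 1 to compound 2, where an aromatic ring left; here one enters, so a modest step downward is expected, written as a 2.8-fold lower number from compound 2 to compound 3 (0.45 log units; beyond the scatter). Compound 3 is therefore estimated at 0.05 ug/mL, with a range from 0.015 ug/mL to 0.2 ug/mL.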

Compound 3, half-maximal effective concentration: > 6.2 ug/mL
Compound 3 was reported as a limit; the forecaster's own chance of this, stated with the estimate: 5%; middle value at least 120-fold (2.09 log units) from the limit.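

At this carbonyl carbon, an aromatic ring does not by itself give a lower number in this assay: 1,2,5-trimethyl-1H-pyrrol-3-yl in place of 1-methylbutyl gives an at least 44-fold higher number from compound 2 to compound 3 (1.64 log units; beyond the scatter). The two aromatic groups also lie far apart, with an at least 250-fold higher number from compound 1 to compound 3 (2.41 log units; beyond the scatter), so the open chain of compound 2 falls between them. Compound 3 is known only as a limit: the limit of > 6.2 ug/mL in this assay, at which 1 of the 3 values shown sits.

As far as these compounds go, it remains open whether the low number of compound 1 depends on the trifluoromethyl group or on the phenyl ring. Also unresolved is where an unsubstituted phenyl, a pyridine or a pyrrole lacking the methyl groups would fall.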